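Heteroaryl replacement on the shared core: notes toward compound 4

The source may report more compounds than this note shows. Statements on the series, on what has been measured and on what is new or still open speak of the compounds shown alone.

Compound 1 `COc1nc(-c2ccc(Br)cc2)ccc1[C@@H](c1ccccc1)[C@@](O)(CCN(C)C)c1cccc2ccccc12` stands at the upper edge of what has been measured in a toxicity assay on HeLa cells (Homo sapiens) for cytotoxicity; on this read-out lower numbers stand for higher toxicity in this test and higher numbers for lower toxicity in this test. In this assay compound 1 gives > 64 ug/mL, which is a limit of the assay and not a number. Compound 2 `COc1nc(-c2ccc(Cl)c(F)c2)ccc1[C@@H](c1ccccc1)[C@@](O)(CCN(C)C)c1cccc2ccccc12` returns a limit as well: in this assay compound 2 gives > 64 ug/mL. Only compound 3 `COc1nc(C2CCOCC2)ccc1[C@@H](c1ccccc1)[C@@](O)(CCN(C)C)c1cccc2ccccc12` yields a number, and in this assay compound 3 gives 22.5 ug/mL. Accordingly a step that the two limits leave unreadable from compound 1 to compound 2 cannot be read, whereas an at least 2.8-fold lower number from compound 1 to compound 3 (0.45 log units; beyond the scatter) and an at least 2.8-fold lower number from compound 2 to compound 3 (0.45 log units; beyond the scatter) both show a drop once an aromatic group gives way to oxan-4-yl. Two of the three values sit at the limit of > 64 ug/mL in this assay, at which 2 of the 3 values shown sit.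

Compound 4 `COc1nc(-c2cnsc2)ccc1[C@@H](c1ccccc1)[C@@](O)(CCN(C)C)c1cccc2ccccc12` differs from compound 1 in one place: 1,2-thiazol-4-yl in place of 4-bromophenyl on an aromatic carbon. For the measured compounds named here, no measured step exchanges one aromatic group for another; the nearest comparisons are the two steps to compound 3, where the number fell. The 1,2-thiazol-4-yl keeps an aromatic ring yet is smaller and carries two hydrogen-bond acceptors, so a number somewhere between compound 1 and compound 3 is expected on the strength of an at least 2.8-fold lower number from compound 1 to compound 3 (0.45 log units; beyond the scatter), with a fair chance that only a limit is reported. For compound 4 the estimated value in this assay is 45 ug/mL, within 20 ug/mL to 90 ug/mL. This estimate amounts to an at least 1.4-fold lower number from compound 1 to compound 4 (0.15 log units; that floor lies within the scatter).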

Compound 4, half-maximal cytotoxic concentration: 28.8 ug/mL
Compound 4: middle estimate off by 1.6-fold (0.19 log units), on the high side; low and high end bracket the measured number.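

In this assay, the place next to the ring nitrogen now shows that the drop in the number does not depend on giving up an aromatic ring: 1,2-thiazol-4-yl gives an at least 2.2-fold lower number from compound 1 to compound 4 (0.34 log units; beyond the scatter) and an at least 2.2-fold lower number from compound 2 to compound 4 (0.34 log units; beyond the scatter). The aromatic 1,2-thiazol-4-yl and the saturated oxan-4-yl cannot be told apart in this test, with a 1.3-fold higher number from compound 3 to compound 4 (0.11 log units; within the scatter). Among the groups shown, only 4-bromophenyl and 4-chloro-3-fluorophenyl leave compound 1 and compound 2 at a limit of the assay rather than at a number: the limit of > 64 ug/mL in this assay, at which 2 of the 4 values shown sit.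

The step between compound 1 and compound 2 cannot be read, and the four compounds do not separate ring size, the hetero atoms and the halogens as the feature that goes with the change at this place. From the compounds shown here alone, how a plain phenyl, a pyridine ring or a carboxylic acid at this place would read in this assay remains open, and such groups would show whether the halogen or the six-membered aromatic ring goes with the limit.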